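A few compounds are considered here, and "the series" means these few. Any claim that something is new, unique, unknown or untested is made for them only; others in the source may bear on it.

Compound 1 `Cn1cc(-c2cnc(NCc3c(F)ccc4c3CCO4)c3cn[nH]c(=O)c23)cn1` gives 21 mL.min-1.g-1
Compound 2 `Cc1nc(CO)ccc1-c1cnc(NCc2c(F)ccc3c2CCO3)c2cn[nH]c(=O)c12` gives 11 mL.min-1.g-1

Among the compounds with values here, in an ADME assay on microsomes from liver (Homo sapiens) for metabolic stability, read by LC-MS, using NADPH, with stated times of 5 min and 30 min, tested at 1 uM (a higher number here means faster removal of the compound, a lower number slower removal), compound 2 stands level with compound 1, the only other measured compound, as the gap between them lies within the scatter. Compound 3 `O=C1CCCN1c1cnc(NCc2c(F)ccc3c2CCO3)c2cn[nH]c(=O)c12` keeps the shared core but has 2-oxopyrrolidin-1-yl in place of 6-(hydroxymethyl)-2-methylpyridin-3-yl on an aromatic carbon. Within the data shown here, one measured step bears on this, an exchange of one group for another at the same place: a 1.9-fold lower number from compound 1 to compound 2 (0.28 log units; within the scatter). That step is small, but neither of its groups is a non-aromatic ring, so it offers only loose guidance. As far as these compounds go, no step beyond the scatter is therefore expected in this assay, and the direction remains open. The expected change is a 1.3-fold higher number from compound 2 to compound 3 (0.10 log units; within the scatter). For compound 3 the estimated value is 14 mL.min-1.g-1, with an expected range from 6 mL.min-1.g-1 to 30 mL.min-1.g-1.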

Compound 3, intrinsic clearance in microsomes: 23 mL.min-1.g-1
The estimate for compound 3 lay 1.6-fold (0.22 log units) below the measured number; the measured number falls inside the stated range.
By their numbers in this assay, from the lowest: compounds 2, 1 and 3 (each within the scatter of the next, the first and the last beyond it).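

Compound 3 is the only compound shown with a non-aromatic ring at this position on an aromatic carbon, and in this assay the exchange of 6-(hydroxymethyl)-2-methylpyridin-3-yl for 2-oxopyrrolidin-1-yl gives a 2.1-fold higher number from compound 2 to compound 3 (0.32 log units; beyond the scatter) and is the only modest step shown beyond the scatter. Set against 1-methyl-1H-pyrazol-4-yl, the same 2-oxopyrrolidin-1-yl group gives a 1.1-fold higher number from compound 1 to compound 3 (0.04 log units; within the scatter) so a five-membered non-aromatic ring can stand level with that aromatic group in this read-out. No measured evidence accounts for either step.

As far as these compounds go, the exchange replaces the whole group at once, so the separate parts played by its hydroxymethyl and methyl substituents remain open. From the compounds shown here alone, how an open-chain amide, an amine or a carboxylic acid would behave at this position also remains open.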